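This account rests on a few compounds, and the source may have more. Where it says the series, first, only, none or still open, it means among the compounds named here.

Of the compounds shown here, three that share one core have been tested in an assay for inhibition of Amine oxidase [flavin-containing] B (Rattus norvegicus); a lower number here means a stronger inhibitor, a higher number a weaker inhibitor. Compound 1 `NC(=O)[C@H](CO)Nc1cc(=O)oc2cc(OCc3cccc(Cl)c3)ccc12` gives 2400 nM. Compound 2 `NC(=O)[C@@H]1CCCN1Cc1cc(=O)oc2cc(OCc3ccccc3)ccc12` gives 380 nM. Compound 3 `NC(=O)[C@@H]1CCCN1Cc1cc(=O)oc2cc(OCc3cccc(F)c3)ccc12` gives 850 nM, the second highest of the three numbers: compound 2 sits closest, compound 1 furthest. Among the measured compounds shown here, the one change from compound 2 to compound 3, fluoro in place of hydrogen on an aromatic carbon, gave a 2.2-fold higher number from compound 2 to compound 3 (0.35 log units; beyond the scatter).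

Compound 4 `NC(=O)Cc1cc(=O)oc2cc(OCc3cccc(F)c3)ccc12` differs from compound 3 in a single place: carbamoyl in place of 2-carbamoylpyrrolidin-1-yl on a saturated chain carbon bound to an aromatic carbon. For the measured compounds named here, no measured step touches this part of the molecule. The step from compound 2 to compound 3 concerns only the fluoro group, and compound 1 carries a different side group with no single-change partner, so the measured data give no direct guide. The change removes the five-membered non-aromatic ring with its one defined stereocentre and leaves a much smaller carbamoyl, and a modestly higher number, with wide uncertainty, is expected as a 2.4-fold higher number from compound 3 to compound 4 (0.37 log units; beyond the scatter). Compound 4 is therefore estimated at 2000 nM in this assay, with a range from 600 nM to 7000 nM.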

Compound 4, half-maximal inhibitory concentration: 50 nM
The estimate for compound 4 lay 40-fold (1.60 log units) above the measured number; the measured number lies below the stated range.
By their numbers in this assay, from the lowest: compound 4; then compound 2; then compound 3; then compound 1.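

In this assay, replacing 2-carbamoylpyrrolidin-1-yl with the much smaller carbamoyl gives a 17-fold lower number from compound 3 to compound 4 (1.23 log units; beyond the scatter), a large step. On a saturated chain carbon bound to an aromatic carbon, then, the five-membered non-aromatic ring and its defined stereocentre are not needed for a low number, at least in this single pair of compounds. Nothing shown here explains why the smaller group gives the lower number.

As far as these compounds go, whether the same change gives a similar step without the fluoro group, starting from compound 2, remains open. Also open, from the compounds shown here alone, is how a simple amine, a carboxylic acid or a longer chain ending in carbamoyl would fare at this place, which could separate the effect of the carbamoyl itself from that of losing the ring.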